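Nitrooxy chain extension from compound 2 to compound 3

The source may hold more compounds than are shown below. What is called first, only, known or untested is meant among the compounds shown, and "the series" means these compounds.

Measured so far in a functional assay on a cell-free system (Platelet, plasma, Oryctolagus cuniculus) for inhibition, read by turbidimetry, with a stated time of 5 min (on this read-out higher numbers stand for weaker inhibition and lower numbers for stronger inhibition), on two compounds:
- compound 1 `CCCCC(OC(=O)CN1CCN(CCCCCCOc2ccc(-c3cc(=S)ss3)cc2)CC1)c1ccccc1C(=O)Oc1ccc(/C=C/C(=O)OCCO[N+](=O)[O-])cc1OC` gives 430000 nM here
- compound 2 `CCCCC(OC(=O)CN1CCN(CCCCCCOc2ccc(-c3cc(=S)ss3)cc2)CC1)c1ccccc1C(=O)Oc1ccc(/C=C/C(=O)OCCCCO[N+](=O)[O-])cc1OC` gives 390000 nM here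

Compound 2 stands level with compound 1 within the scatter. The change to compound 3 `CCCCC(OC(=O)CN1CCN(CCCCCCOc2ccc(-c3cc(=S)ss3)cc2)CC1)c1ccccc1C(=O)Oc1ccc(/C=C/C(=O)OCCCCCCO[N+](=O)[O-])cc1OC` is 2-(nitrooxy)ethyl in place of nitrooxy on a saturated chain carbon, four bonds along the chain from an oxygen next to a carbonyl group and reads 2-(nitrooxy)ethyl in place of nitrooxy on a saturated chain carbon, four bonds along the chain from an oxygen next to a carbonyl group. For the measured compounds named here, the one measured step of this kind, two bonds along the chain, is a 1.1-fold lower number from compound 1 to compound 2 (0.04 log units; within the scatter) and stays within the scatter. No move beyond the scatter is expected in this assay with the estimated step being a 1.0-fold lower number from compound 2 to compound 3 (0.01 log units; within the scatter) and nothing larger. The estimate for compound 3 is 380000 nM with 190000 nM to 750000 nM as the expected range.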

Compound 3, half-maximal inhibitory concentration: 190000 nM
Beside the measured number, compound 3's estimate is 2.0-fold (0.30 log units) above it; measured number inside the range.
By their numbers in this assay, from the lowest: compound 3; then compounds 2 and 1 (each within the scatter of the next).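

In this assay, for the compounds shown here, the longest nitrooxy chain is the first to move the number beyond the scatter: 2-(nitrooxy)ethyl in place of nitrooxy, four bonds along the chain from an oxygen next to a carbonyl group, gives a 2.1-fold lower number from compound 2 to compound 3 (0.31 log units; beyond the scatter), and 4-(nitrooxy)butyl in place of nitrooxy, two bonds along the chain from that oxygen, gives a 2.3-fold lower number from compound 1 to compound 3 (0.35 log units; beyond the scatter). This position therefore responds to chain length, though only modestly. No measurement on hand accounts for the shift.
On these data alone, whether a longer chain lowers the number further or levels off remains open, as does whether the nitrooxy end matters, which a hydroxyl or carboxylic acid on the same chain would test.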